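Aryl change on the saturated ring carbon: compound 4

This account rests on a few compounds, and the source may have more. Where it says the series, first, only, none or still open, it means among the compounds named here.

Measured so far in a functional assay on A549 cells (Homo sapiens) for antiproliferative activity, read by MTT assay, with a stated time of 96 h; on this read-out higher numbers stand for weaker inhibition and lower numbers for stronger inhibition:
compound 1 `CCOC(=O)/C=C1/SC(N2N=C(c3cc4ccccc4o3)CC2c2ccc(F)cc2)=NC1=O` gives 0.93 ug/mL
compound 2 `CCOC(=O)/C=C1/SC(N2N=C(c3cc4ccccc4o3)CC2c2ccc(OC)c(OC)c2)=NC1=O` gives 3.42 ug/mL
compound 3 `CCOC(=O)/C=C1/SC(N2N=C(c3cc4ccccc4o3)CC2c2cccc(Br)c2)=NC1=O` gives > 5 ug/mL, which is a limit of this assay and not a number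

Compound 3 thus sits at the weak end of the three, at the limit of > 5 ug/mL in this assay, at which 1 of the 3 values shown sits. The steps of an at least 5.3-fold higher number from compound 1 to compound 3 (0.73 log units; beyond the scatter) and an at least 1.4-fold higher number from compound 2 to compound 3 (0.16 log units; that floor lies within the scatter) both run toward that limit, while a 3.7-fold higher number from compound 1 to compound 2 (0.57 log units; beyond the scatter) separates the two numbered compounds. Compound 4 `CCOC(=O)/C=C1/SC(N2N=C(c3cc4ccccc4o3)CC2c2ccc(OC)cc2)=NC1=O` differs from compound 3 by 4-methoxyphenyl in place of 3-bromophenyl on a saturated ring carbon. Going by the values given here, no measured step carries this exact change, so the expectation rests on the 4-fluorophenyl and 3,4-dimethoxyphenyl analogues, compounds 1 and 2, which both give numbers in this assay. Compound 4 is expected near 2 ug/mL, with a range from 0.7 ug/mL to 6 ug/mL. The step of an at least 2.5-fold lower number from compound 3 to compound 4 (0.39 log units; beyond the scatter) is therefore estimated as a move from the limit to a lower number.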

Compound 4, half-maximal inhibitory concentration: 1.21 ug/mL
Beside the measured number, compound 4's estimate is 1.7-fold (0.22 log units) above it; the measured number falls inside the stated range.
By their numbers in this assay, from the lowest: compounds 1 and 4 (each within the scatter of the next); then compound 2. At a limit, above all of these: compound 3.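

In this assay, compound 3 stands at a limit and not a number: the limit of > 5 ug/mL in this assay, at which 1 of the 4 values shown sits.

Against that limit, 4-methoxyphenyl in place of 3-bromophenyl on the saturated ring carbon gives an at least 4.1-fold lower number from compound 3 to compound 4 (0.61 log units; beyond the scatter), a floor that lies clear of the scatter. Hydrogen in place of methoxy on an aromatic carbon gives a 2.8-fold lower number from compound 2 to compound 4 (0.45 log units; beyond the scatter), whereas methoxy in place of fluoro on an aromatic carbon gives a 1.3-fold higher number from compound 1 to compound 4 (0.11 log units; within the scatter), so the 4-methoxyphenyl and 4-fluorophenyl groups are not told apart here.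

Open, as far as these compounds go, is how a 4-bromophenyl or a 4-aminophenyl group would read on this carbon.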